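The source may report more compounds than this note shows. Statements on the series, on what has been measured and on what is new or still open speak of the compounds shown alone.

- Compound 1 `COC[C@H](C)[C@H](C)C(c1ccc(O)c(OC)c1)c1ccc(O)c(OC)c1`: 82000 nM
- Compound 2 `COc1cc(C(c2ccc(O)c(OC)c2)[C@H](C)C(C)C)ccc1O`: 17000 nM
- Compound 3 `COc1cc(C(c2ccc(O)c(OC)c2)[C@@H](C)[C@H](C)CO)ccc1O`: > 100000 nM (a limit)

Compound 3 has no number in a functional assay on HL-60 cells (Homo sapiens) for cytotoxicity, read by WST assay, with a stated time of 48 h (a higher number here means a weaker inhibitor, a lower number a stronger inhibitor), only the limit > 100000 nM.

Compound 4 `COc1cc(C(c2ccc(O)c(OC)c2)[C@@H](C)[C@H](C)CF)ccc1O` carries fluoro in place of hydroxy on a saturated chain carbon, four bonds along the chain from two aromatic carbons.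

Three measured steps change this same chain. Exchanging the chain for 1,2-dimethylpropyl gave a 4.8-fold lower number from compound 1 to compound 2 (0.68 log units; beyond the scatter). Putting 2-(hydroxymethyl)-1-methylpropyl in its place gave an at least 5.8-fold higher number from compound 2 to compound 3 (0.76 log units; beyond the scatter). Exchanging 1-(methoxymethyl)ethyl for 1-(hydroxymethyl)ethyl gave an at least 1.2-fold higher number from compound 1 to compound 3 (0.08 log units; that floor lies within the scatter), whose floor lies within the scatter.

No fluoromethyl chain has been measured, so the guide is the span from compound 2 at 17000 nM to compound 1 at 82000 nM. In this assay a modest move to a lower number is therefore expected, and that expected step is an at least 2.2-fold lower number from compound 3 to compound 4 (0.34 log units; beyond the scatter).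

The estimated value for compound 4 is 45000 nM, with an expected range of 15000 nM to 100000 nM.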

Compound 4, half-maximal inhibitory concentration: 32000 nM
Beside the measured number, compound 4's estimate is 1.4-fold (0.15 log units) above it; the range from low to high includes it.
By their numbers in this assay, from the lowest: compounds 2 and 4 (each within the scatter of the next); then compound 1. At a limit, above all of these: compound 3.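

In this assay, fluoro in place of hydroxy on a saturated chain carbon, four bonds along the chain from two aromatic carbons, gives an at least 3.1-fold lower number from compound 3 to compound 4 (0.49 log units; beyond the scatter), showing that the end of this chain responds to a single-atom exchange. Compound 3 stands only at a limit, so this step is a floor and not a measured size: the limit of > 100000 nM in this assay, at which 1 of the 4 values shown sits. The fluoromethyl chain gives a 1.9-fold higher number from compound 2 to compound 4 (0.27 log units; within the scatter), and it also gives a 2.6-fold lower number from compound 1 to compound 4 (0.41 log units; beyond the scatter), so with fluoro at this carbon the extended chain no longer separates from the unsubstituted 1,2-dimethylpropyl chain beyond the scatter.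

As far as these compounds go, how far the step from hydroxy to fluoro truly reaches stays open, since compound 3 has no number. From the compounds shown here alone, it also remains open whether an amine, a chloro group or a longer chain at this carbon would follow fluoro or hydroxy.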